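The source may report more compounds than this note shows. Statements on the series, on what has been measured and on what is new or still open speak of the compounds shown alone.

Measured compounds:
Compound 1, `CCSc1nc2c(cc(-c3ccccc3)n2-c2ccccc2)c(=N)s1`: in a functional assay on the whole organism for inhibition, with Rattus norvegicus as the target, read by ELISA, with stated times of 30 min and 6 h, at a dose of 30 mg/kg by the oral route (a higher number here means more inhibition at the dose given (going by the name of the read-out), a lower number less inhibition), compound 1 gives 0%.
Compound 2, `CCC(C)Sc1nc2c(cc(-c3ccccc3)n2-c2ccccc2)c(=N)s1`: in this assay compound 2 gives 50%.

Within the data shown here, compound 2 stands highest of the two numbers; its nearest neighbour is compound 1, and the only measured step, a number 50 percentage points higher from compound 1 to compound 2 (beyond the scatter), separates them. Compound 3, `CCC(C)Sc1nc2c(cc(-c3ccc(C)cc3)n2-c2ccccc2)c(=N)s1`, has not yet been measured. It differs from compound 2 in one place: methyl in place of hydrogen on an aromatic carbon. The methyl enters on an aromatic carbon of a six-membered aromatic ring of carbon only, para to a large group; cut one bond further out, the difference reads phenyl to 4-methylphenyl.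

Among the measured compounds shown here, only one step has been measured, a number 50 percentage points higher from compound 1 to compound 2 (beyond the scatter), and it concerns the chain on the sulfur, not the aromatic ring. For the measured compounds named here, it was large, but it says nothing about a methyl on the ring, and no measured pair shows what such a methyl does. With no guide, the expected step in this assay is none beyond the scatter. The estimate for compound 3 is 48%, in the range 15% to 80%, which means an expected step of a number 2 percentage points lower from compound 2 to compound 3 (within the scatter). The range is wide: the number rests on compound 2 alone.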

Compound 3, a percentage reported as inhibition, in the whole organism at one dose (the size of the read-out at that dose, not a potency): 2%
Estimate against measurement, compound 3: 46 percentage points above; the whole stated range lies above it.
By their numbers in this assay, from the lowest: compounds 1 and 3 (each within the scatter of the next); then compound 2.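

The change from phenyl to 4-methylphenyl gives a number 48 percentage points lower from compound 2 to compound 3 (beyond the scatter) in this assay, so the aromatic ring carrying this methyl, and not only the chain on the sulfur, has a large bearing on the read-out at this dose. A single added carbon, on an aromatic carbon para to a large group, is enough to produce this large step, which makes this position sensitive to even the smallest carbon substituent in this one pair. Nothing available here explains why a methyl at this place has such an effect on inhibition in the whole animal.

The compounds shown leave open whether this loss is particular to methyl or would also follow from another group on the same carbon, such as a chlorine atom, a methoxy group or a carboxylic acid. They also leave open whether a methyl on the other phenyl ring of the shared core would give a similar step, and whether a longer chain on the sulfur would change the result seen with 4-methylphenyl.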